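The source may report more compounds than this note shows. Statements on the series, on what has been measured and on what is new or still open speak of the compounds shown alone.

Compound 1 `O=C1NC(O)C(F)=CN1[C@H]1C=C[C@@H](CO)O1` with 59300 nM
Compound 2 `Nc1nc(=O)n([C@H]2C=C[C@@H](CO)O2)cc1Br` with > 100000 nM (a limit of the assay, not a number)

Both values come from a functional assay on HepG2 cells (Homo sapiens) for antiproliferative activity (on this read-out higher numbers stand for weaker inhibition and lower numbers for stronger inhibition), and no other data are available. Compound 2 stands only at a limit of the assay (> 100000 nM) and so has no exact position on the scale. This is also seen in the limit of > 100000 nM in this assay, at which 1 of the 2 values shown sits, and it leaves no firm starting point. Compound 3 `Nc1nc(=O)n([C@H]2C=C[C@@H](CO)O2)cc1I` has iodo in place of bromo on an aromatic carbon and is otherwise the same as compound 2. Among the measured compounds shown here, no measured step shows what this exchange does. In this assay the expected change (a number no higher from compound 2 to compound 3 (the limit leaves the size open)) is none beyond the scatter, in either direction. For compound 3 the estimated value is 100000 nM within an expected range of 45000 nM to 200000 nM and it may well prove to be a limit again.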

Compound 3, half-maximal inhibitory concentration: > 100000 nM
Compound 3: no number, only a limit; the forecaster's own chance of this, stated with the estimate: 60%; the middle value lies on the limit itself.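

In this assay compound 3 gives > 100000 nM, a limit of the assay and not a number. Compound 2 stands at a limit too, so no step between compound 2 and compound 3 can be read: the limit of > 100000 nM in this assay, at which 2 of the 3 values shown sit.

Going by these compounds, what iodo in place of bromo does in this assay stays open, as does the exact position of compound 2 and compound 3 on the scale.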